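The compounds below may be only part of what the source reports. "The series", "measured", "known", "first", "only" and "open" are said of these compounds alone.

Compound 1 `CCCON1C(=O)[C@@H](NC(=O)OCCCCC2CCCCC2)[C@@H]1C` stands highest of the two numbers in an assay on HEK293 cells for inhibition of N-acylethanolamine-hydrolyzing acid amidase (Homo sapiens), read by fluorescence, with stated times of 10 min and 50 min (on this read-out lower numbers stand for stronger inhibition and higher numbers for weaker inhibition), where compound 1 gives 133 nM. Its nearest neighbour, compound 2 `CC(=O)CCCON1C(=O)[C@@H](NC(=O)OCCCCC2CCCCC2)[C@@H]1C`, gives 75 nM in this assay, and the step of a 1.8-fold lower number from compound 1 to compound 2 (0.25 log units; within the scatter) is the only measured one; it does not touch the oxygen that changes here. Compound 3 `C[C@H]1[C@H](NC(=O)OCCCCC2CCCCC2)C(=O)N1Oc1ccc(C(F)(F)F)cc1` differs from compound 1 by 4-(trifluoromethyl)phenyl in place of propyl on an oxygen. Going by the values given here, no measured step bears on this change, so no direction beyond the scatter is expected in this assay, only a wide uncertainty. Compound 3 is estimated at 110 nM, between 30 nM and 400 nM, an expected step of a 1.2-fold lower number from compound 1 to compound 3 (0.08 log units; within the scatter).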

Compound 3, half-maximal inhibitory concentration: 31 nM
The estimate for compound 3 lay 3.5-fold (0.55 log units) above the measured number, within the range that was stated.
By their numbers in this assay, from the lowest: compound 3; then compounds 2 and 1 (each within the scatter of the next).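

On the oxygen whose other neighbour is the amide-type nitrogen in a ring, the earlier compounds had shown only a change within the scatter, made on a chain. In this assay, an aromatic ring at this place gives a step beyond the scatter, with 4-(trifluoromethyl)phenyl in place of propyl giving a 4.3-fold lower number from compound 1 to compound 3 (0.63 log units; beyond the scatter), and in place of 3-acetylpropyl giving a 2.4-fold lower number from compound 2 to compound 3 (0.38 log units; beyond the scatter). Nothing available explains this result. As far as these compounds go, it remains open whether the ring or the trifluoromethyl group carries the step, and how a plain phenyl or a chain ending in an amine would read.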